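The source may hold more compounds than are shown below. What is called first, only, known or untested is meant among the compounds shown, and "the series" means these compounds.

Measured compounds:
compound 1 `CCCCCNc1nc(N)c2nc(O)n(Cc3ccccc3)c2n1` — 0.3 mg/kg
compound 2 `Nc1nc(SCc2ccccc2)nc2c1nc(O)n2Cc1ccccc1` — > 1 mg/kg
compound 3 `Nc1ncnc2c1nc(O)n2Cc1ccccc1` — 30 mg/kg

In a functional assay on the whole organism for activation, with Mus musculus as the target (on this read-out lower numbers stand for an effect already at smaller amounts and higher numbers for an effect only at larger amounts of compound), compound 2 reached only a limit of the assay, not a number. Its step to compound 3 is therefore unreadable because of the limit of > 1 mg/kg in this assay, at which 1 of the 3 values shown sits. Compound 4 `CCCOc1nc(N)c2nc(O)n(Cc3ccccc3)c2n1` differs from compound 2 by propoxy in place of benzylsulfanyl on an aromatic carbon. Going by the values given here, the steps that bear on this are an at least 3.3-fold higher number from compound 1 to compound 2 (0.52 log units; beyond the scatter) and a 100-fold higher number from compound 1 to compound 3 (2.00 log units; beyond the scatter): the change to hydrogen gives a large step, while the change to benzylsulfanyl gives at least a modest one. Propoxy keeps a short chain at this carbon, so a number between compound 1 and compound 3 is expected, and the expected step is a number no higher from compound 2 to compound 4 (the limit leaves the size open). Compound 4 is estimated at 1 mg/kg, with a range from 0.3 mg/kg to 3 mg/kg.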

Compound 4, minimum effective dose: 0.3 mg/kg
Beside the measured number, compound 4's estimate is 3.3-fold (0.52 log units) above it, and the stated range covers the measured number.
By their numbers in this assay, from the lowest: compounds 1 and 4 (each within the scatter of the next); then compound 3.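

At the carbon between two ring nitrogen atoms, pentylamino is not required in this assay: propoxy gives no change at the digits printed from compound 1 to compound 4 (within the scatter). Compared with hydrogen at this carbon, propoxy gives a 100-fold lower number from compound 3 to compound 4 (2.00 log units; beyond the scatter). Compared with benzylsulfanyl, it gives an at least 3.3-fold lower number from compound 2 to compound 4 (0.52 log units; beyond the scatter), a step that shows that the group leaving, not the carbon itself, sets the difference between these two compounds.

The compounds shown do not separate the sulfur from the aromatic ring of benzylsulfanyl, which a propylsulfanyl or benzyloxy group would do. On these data alone, how a longer alkoxy chain or a carboxylic acid would fare at this carbon remains open.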